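Swapping the aryl amide of compound 2 for difluorophenyl

A few compounds are considered here, and "the series" means these few. Any claim that something is new, unique, unknown or untested is made for them only; others in the source may bear on it.

Measured so far:
- Compound 1 `CC(C)(C)C(=O)N1Cc2c(NC(=O)c3ccncc3)n[nH]c2C1(C)C` gives 110 nM in a functional assay on A2780 cells (Homo sapiens) for antiproliferative activity, read by fluorescence, with a stated time of 72 h; a lower number here means a stronger inhibitor, a higher number a weaker inhibitor
- Compound 2 `CN1CCC(C(=O)N2Cc3c(NC(=O)c4ccsc4)n[nH]c3C2(C)C)CC1` gives 140 nM in this assay

Two compounds share a common core and carry different groups on the carbonyl carbon of the amide. Compound 1 carries pyridin-4-yl there and compound 2 carries thiophen-3-yl. In this assay compound 2 shows the higher of the two numbers, but its gap to compound 1 sits within the scatter of repeated measurements, so the two values cannot be told apart and neither compound can be called the stronger one.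

Compound 3 `CN1CCC(C(=O)N2Cc3c(NC(=O)c4cc(F)cc(F)c4)n[nH]c3C2(C)C)CC1` has not yet been tested. Its relation to compound 2 is a single change: 3,5-difluorophenyl in place of thiophen-3-yl on a carbonyl carbon. Among the compounds with values here, nothing among the measured compounds shows what replacing one aromatic group by another at this position does, since the only two values in hand are indistinguishable. The step from compound 2 to compound 3 is therefore expected to be small, in either direction or none beyond the scatter, as a 1.1-fold higher number from compound 2 to compound 3 (0.03 log units; within the scatter) expresses. Compound 3 is expected to give about 150 nM in this assay, with a plausible range from 50 nM to 450 nM.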

Compound 3, half-maximal inhibitory concentration: 130 nM
For compound 3 the middle estimate is 1.2-fold (0.06 log units) above the measured one, within the range that was stated.
By their numbers in this assay, from the lowest: compounds 1, 3 and 2 (each within the scatter of the next).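

In this assay, within the data shown here, the step from thiophen-3-yl to 3,5-difluorophenyl on this carbonyl carbon is a 1.1-fold lower number from compound 2 to compound 3 (0.03 log units; within the scatter), which gives the first direct reading of a change at this position with the rest of the molecule held fixed. In this pair, a five-membered aromatic ring containing sulfur and a six-membered aromatic ring of carbon only, carrying two fluorine atoms, cannot be told apart by their values, so this exchange leaves antiproliferative activity unchanged within the scatter. Nothing available explains this outcome or shows how either group acts on the cells.

Among these compounds, this single pair covers only two aromatic groups, so it remains open whether the same holds for a non-aromatic group such as cyclohexyl, or for a phenyl ring carrying an amine or a carboxylic acid. Compound 1 differs from compound 2 in more than one place, so the effect of pyridin-4-yl at this position cannot be separated from that of the other difference between them.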